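Replacing furan-2-yl with pyridin-3-yl on the amide carbonyl

This account rests on a few compounds, and the source may have more. Where it says the series, first, only, none or still open, it means among the compounds named here.

In an ADME assay for pharmacokinetics (on this read-out lower numbers stand for a shorter-lived compound and higher numbers for a longer-lived compound), compound 1 (`CC(=O)Nc1nc2nc(C)ncc2cc1-c1c(Cl)cccc1Cl`) gives < 0.0834 h, which is a limit of the assay and not a number. For the measured compounds named here, compound 2 (`Cc1ncc2cc(-c3c(Cl)cccc3Cl)c(NC(=O)c3ccco3)nc2n1`) gives 4 h, the only actual number so far.

Compound 3 (`Cc1ncc2cc(-c3c(Cl)cccc3Cl)c(NC(=O)c3cccnc3)nc2n1`) differs from compound 2 at the same place: pyridin-3-yl in place of furan-2-yl on a carbonyl carbon. In words, pyridin-3-yl stands in place of furan-2-yl on a carbonyl carbon.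

Going by the values given here, one measured step bears on this place: an at least 47-fold higher number from compound 1 to compound 2 (1.68 log units; beyond the scatter), with furan-2-yl in place of methyl on a carbonyl carbon. That large step shows that the group on the carbonyl can shift the number in this assay, but it started from methyl, not from an aromatic ring. Among the compounds with values here, no measured step links one aromatic ring to another, so its size is not expected to carry over, and the direction remains poorly defined. A slight drop is expected at most, with compound 2 at 4 h as the anchor. The expected change is a 1.6-fold lower number from compound 2 to compound 3 (0.20 log units; within the scatter), a small step. For compound 3 the estimate is 2.5 h, with an expected range from 0.7 h to 6 h.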

Compound 3, half-life: 4 h
Compound 3: middle estimate off by 1.6-fold (0.20 log units), on the low side; measured number inside the range.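

In this assay, putting pyridin-3-yl in place of furan-2-yl on the carbonyl carbon gives no change at the digits printed from compound 2 to compound 3 (within the scatter), so a five-membered and a six-membered aromatic ring cannot be told apart at this position on this read-out. Putting pyridin-3-yl in place of methyl gives an at least 47-fold higher number from compound 1 to compound 3 (1.68 log units; beyond the scatter), so the large step out of compound 1 is no longer tied to furan-2-yl alone and appears with both aromatic rings shown. The value of compound 1 is a limit and not a number, so the full size of both steps from methyl remains unknown: the limit of < 0.0834 h in this assay, at which 1 of the 3 values shown sits.

The three compounds do not show whether an aromatic ring is needed at all, and a saturated ring such as cyclohexyl or a longer chain such as butyl on the carbonyl carbon would test that directly. They also leave open how far the flat result holds among aromatic rings, for example with pyridin-2-yl, or with phenyl carrying an amine or a carboxylic acid.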